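A few compounds are considered here, and "the series" means these few. Any claim that something is new, unique, unknown or untested is made for them only; others in the source may bear on it.

For the measured compounds named here, compound 1 `CC(=O)O[C@@H]1OC(=O)[C@](Cc2ccccc2)(C(C)=O)[C@@H]1C` is the only compound with a definite number in a functional assay on DA-3 cells for cytotoxicity against DA-3 cell line (Mus musculus), read by MTT assay; a lower number here means a stronger inhibitor, a higher number a weaker inhibitor; there compound 1 gives 45000 nM. Compound 2 `CC(=O)O[C@@H]1OC(=O)[C@](O)(C(C)=O)[C@@H]1C` carries a hydroxy in place of the benzyl on a saturated ring carbon. In this assay compound 2 reaches only a limit of the assay, > 50000 nM, which is one of the two values shown (the limit of > 50000 nM in this assay, at which 1 of the 2 values shown sits). The step from compound 1 to compound 2 amounts to an at least 1.1-fold higher number from compound 1 to compound 2 (0.04 log units; that floor lies within the scatter). Compound 3 `CC(=O)O[C@@H]1OC(=O)[C@@](Cc2ccccc2)(C(C)=O)[C@@H]1C` keeps every atom and bond of compound 1 and differs only in configuration as drawn: the two compounds have the same atoms and bonds and differ only in configuration as drawn: 1 of 3 stereo elements differ; a stereocentre at a saturated ring carbon is drawn S in compound 1 and R in compound 3. Going by the values given here, no measured step changes configuration alone, and the single measured step is a floor lying within the scatter, so it offers no guide of its own. From compound 1 to compound 3 the expected change is no change at the digits printed from compound 1 to compound 3 (within the scatter), nothing beyond the scatter. Compound 3 is therefore estimated at 45000 nM, with a range from 15000 nM to 100000 nM.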

Compound 3, half-maximal inhibitory concentration: 44000 nM
The estimate for compound 3 lay 1.0-fold (0.01 log units) above the measured number, and the stated range covers the measured number.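

The change from S to R at this saturated ring carbon gives a 1.0-fold lower number from compound 1 to compound 3 (0.01 log units; within the scatter) in this assay, so this change of configuration alone does not move the number beyond the scatter. The earlier step could not show this, since it also exchanged the benzyl for a hydroxy. Compound 2 gives > 50000 nM, which is a limit of the assay, so that step gave only a floor. This pair is the first with two definite numbers, and the comparison isolates the stereocentre: the fact that compounds 1 and 3 differ only in the configuration as drawn

The compounds shown leave open how the number responds at this carbon to groups such as an amine, a carboxylic acid or a longer alkyl chain in place of the benzyl. They also leave open whether changing the configuration at the remaining stereo elements would matter.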